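The source may hold more compounds than are shown below. What is called first, only, known or untested is meant among the compounds shown, and "the series" means these compounds.

Measured compounds:

Compound 1 `CCN(CC)C(=O)CN(c1cc(Cl)ccc1OC)S(=O)(=O)c1ccccc1` — in a functional assay on SH-SY5Y cells (Homo sapiens), read by MTT assay, with a stated time of 24 h (on this read-out higher numbers stand for an effect only at larger amounts of compound and lower numbers for an effect already at smaller amounts), compound 1 reaches only the limit of the assay, > 20000 nM.
Compound 2 `COc1ccc(Cl)cc1N(CC(=O)N1CCCCC1)S(=O)(=O)c1ccccc1` — in this assay compound 2 gives 14500 nM.
Compound 3 `COc1ccccc1NC(=O)CN(c1cc(Cl)ccc1OC)S(=O)(=O)c1ccccc1` — in this assay compound 3 gives 15500 nM.

Within the data shown here, compound 2 and compound 3 stand level with each other, the step of a 1.1-fold higher number from compound 2 to compound 3 (0.03 log units; within the scatter) staying within the scatter; compound 1 gives a limit rather than a number, so only two numbers exist. Compound 4 `COc1ccc(Cl)cc1N(CC(=O)NC1CCCCC1)S(=O)(=O)c1ccccc1` is not yet measured. It differs from compound 2 by one change: cyclohexylamino in place of piperidin-1-yl on a carbonyl carbon.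

Among the measured compounds shown here, two measured steps touch the same position on the carbonyl carbon. The step of an at least 1.3-fold lower number from compound 1 to compound 2 (0.13 log units; that floor lies within the scatter) has its floor within the scatter, and the step of an at least 1.2-fold lower number from compound 1 to compound 3 (0.11 log units; that floor lies within the scatter) likewise; the step of a 1.1-fold higher number from compound 2 to compound 3 (0.03 log units; within the scatter) is within the scatter. All three changes at this position therefore moved the number little, if at all, in this assay. The exchange from compound 2 to compound 4 is expected to behave the same way, with no step beyond the scatter, no change at the digits printed from compound 2 to compound 4 (within the scatter). Compound 4 is estimated at 14500 nM, between 7000 nM and 30000 nM.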

Compound 4, half-maximal effective concentration: 17600 nM
Compound 4: middle estimate off by 1.2-fold (0.08 log units), on the low side, within the range that was stated.
By their numbers in this assay, from the lowest: compounds 2, 3 and 4 (each within the scatter of the next). At a limit, above all of these: compound 1.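

In this assay, bringing in cyclohexylamino adds the amide hydrogen and a ring of carbon only, yet the number stays within the scatter, with a 1.2-fold higher number from compound 2 to compound 4 (0.08 log units; within the scatter). Among these compounds, a saturated ring on the amide-type nitrogen also stands level with the aromatic 2-methoxyphenyl, with a 1.1-fold higher number from compound 3 to compound 4 (0.06 log units; within the scatter), a comparison the earlier compounds did not offer. Against diethylamino there is an at least 1.1-fold lower number from compound 1 to compound 4 (0.05 log units; that floor lies within the scatter), which is only a floor, as compound 1 gives a limit and not a number.

As far as these compounds go, whether any group on this carbonyl carbon can move the number beyond the scatter stays open, for example a piperazin-1-yl ring, a carboxylic acid or a longer chain ending in an amine. What a change elsewhere on the shared core would do, such as a nitrile in place of the chlorine, is open too.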